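A Fluorine Added Beside the Methoxy Group

The source may hold more compounds than are shown below. What is called first, only, known or untested is meant among the compounds shown, and "the series" means these compounds.

Of the compounds shown here, two of one shared core have been measured in a functional assay on CHO/Galpha16 cells for antagonist activity at prostaglandin E2 receptor EP3 subtype (Homo sapiens), read by calcium flux, with a stated time of 15 min; a higher number here means a weaker inhibitor, a lower number a stronger inhibitor. Compound 1, `C[C@H](NC(=O)c1c(NCc2ccc(C(F)(F)F)cc2)sc2c1CCOC2)c1ccc(C(=O)O)cc1`, gives > 10000 nM, which is a limit of the assay rather than a number. Compound 2, `COc1ccc(Cc2sc3c(c2C(=O)N[C@@H](C)c2ccc(C(=O)O)cc2)CCOC3)cc1`, gives > 10000 nM, also a limit of the assay. Among the measured compounds shown here, compound 2 therefore stands at the limit of > 10000 nM in this assay, at which 2 of the 2 values shown sit, and no step between measured compounds can be read from these two values.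

Compound 3, `COc1ccc(Cc2sc3c(c2C(=O)N[C@@H](C)c2ccc(C(=O)O)cc2)CCOC3)cc1F`, is not yet measured. It differs from compound 2 in one place: fluoro in place of hydrogen on an aromatic carbon, ortho to the methoxy group and meta to a large group. Since both measured values are limits, no direction for such a change can be drawn from them. The expected step from compound 2 to compound 3 is a number no higher from compound 2 to compound 3 (the limit leaves the size open), which is expected to lie within the usual scatter. Compound 3 is accordingly expected to give about 10000 nM in this assay, between 3000 nM and 30000 nM, most likely reported again only as a limit.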

Compound 3, half-maximal inhibitory concentration: > 10000 nM
Compound 3 gave a limit, no number (the forecaster's own chance of this, stated with the estimate: 80%); the middle value sits exactly at the limit.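

In this assay compound 3 gives > 10000 nM, again a limit of the assay and not a number. Compound 2 also gave only a limit, so no step can be read between compound 2 and compound 3: the limit of > 10000 nM in this assay, at which 3 of the 3 values shown sit.

The compounds shown leave open what number, if any, this shared core would reach in this assay, and whether the fluoro changes it.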